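Hydroxypropyl in Place of an Ester on a Triazole

The source may report more compounds than this note shows. Statements on the series, on what has been measured and on what is new or still open speak of the compounds shown alone.

compound 1 `CCOC(=O)Cn1cc(-c2ccc3ccccc3c2)nn1` — > 100000 nM
compound 2 `OC(c1ccc(C(F)(F)F)cc1)c1cn(Cc2ccccc2)nn1` — > 100000 nM

In a functional assay on B16 cells (Mus musculus) for cytotoxicity, read by MTT assay, with a stated time of 48 h (a lower number here means a stronger inhibitor, a higher number a weaker inhibitor), compound 1 gives > 100000 nM, which is a limit of the assay rather than a number. Compound 2 likewise gives only a limit, > 100000 nM. Both values sit at the limit of > 100000 nM in this assay, at which 2 of the 2 values shown sit. Compound 3 `OCCCn1cc(-c2ccc3ccccc3c2)nn1` has not yet been measured; it differs from compound 1 by 2-hydroxyethyl in place of ethoxycarbonyl on a saturated chain carbon bound to an aromatic nitrogen. Among the compounds with values here, no step between measured compounds has been followed here, so nothing shows how large such a change is. The expected step that the limit leaves unreadable from compound 1 to compound 3 is none beyond the scatter, most likely again ending at a limit. Compound 3 is estimated at 150000 nM, within 40000 nM to 600000 nM.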

Compound 3, half-maximal inhibitory concentration: > 100000 nM
Compound 3: only a limit was reported (the forecaster's own chance of this, stated with the estimate: 80%); the middle value is on the limit's open side.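

Compound 1 and compound 3 both give only a limit, so replacing ethoxycarbonyl with 2-hydroxyethyl yields no readable step: the limit of > 100000 nM in this assay, at which 3 of the 3 values shown sit.

The compounds shown leave open how strongly any of them would act in this assay, and whether this change matters at all.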